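The compounds below may be only part of what the source reports. "The series", "measured", "known", "first", "only" and "open" are said of these compounds alone.

Among the compounds with values here, in a functional assay on M14 cells (Homo sapiens) for antiproliferative activity, read by sulforhodamine B assay, with a stated time of 48 h (on this read-out higher numbers stand for weaker inhibition and lower numbers for stronger inhibition), the three measured members differ only in the group on the carbonyl carbon. Compound 1 `COc1cc(-c2nn(-c3ccc(NC(=O)Nc4ccc(Cl)c(Cl)c4)cc3)cc2-c2ccncc2)ccc1Cl` gives 2560 nM, compound 3 `COc1cc(-c2nn(-c3ccc(NC(=O)c4ccc(Cl)c(C(F)(F)F)c4)cc3)cc2-c2ccncc2)ccc1Cl` gives 1920 nM, and compound 2 `COc1cc(-c2nn(-c3ccc(NC(=O)c4cc(Cl)cc(Cl)c4)cc3)cc2-c2ccncc2)ccc1Cl` gives 7390 nM, the highest number of the three. Both a 2.9-fold higher number from compound 1 to compound 2 (0.46 log units; beyond the scatter) and a 3.8-fold lower number from compound 2 to compound 3 (0.59 log units; beyond the scatter) lie beyond the scatter, while a 1.3-fold lower number from compound 1 to compound 3 (0.12 log units; within the scatter) does not. Compound 4 `O=C(Nc1ccc(-n2cc(-c3ccncc3)c(-c3ccc(Cl)c(O)c3)n2)cc1)c1cc(Cl)cc(Cl)c1` keeps the carbonyl side of compound 2 and changes the other end: hydrogen in place of methyl on an oxygen on an aromatic ring. Within the data shown here, no measured step touches this oxygen; every step so far moves the amide substituent instead. With nothing to set a direction, a change within the scatter is expected, so the estimated step is a 1.1-fold lower number from compound 2 to compound 4 (0.02 log units; within the scatter). Compound 4 is therefore expected near 7000 nM, within 2500 nM to 20000 nM.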

Compound 4, half-maximal inhibitory concentration: 1510 nM
For compound 4 the middle estimate is 4.6-fold (0.67 log units) above the measured one; measured number below the stated range.
By their numbers in this assay, from the lowest: compounds 4, 3 and 1 (each within the scatter of the next); then compound 2.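

Within the data shown here, the methoxy-bearing end, which no earlier step touched, also moves the number in this assay: hydroxy in place of methoxy gives a 4.9-fold lower number from compound 2 to compound 4 (0.69 log units; beyond the scatter), towards stronger inhibition. This rests on a single pair, carrying the 3,5-dichlorophenyl group on the carbonyl carbon. Nothing available accounts for the change. From the compounds shown here alone, whether it carries over to the carbonyl substituents of compound 1 and compound 3 stays open. Also open, going by these compounds, is how an ethoxy group or an amine would read at this place on the ring.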